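The source may hold more compounds than are shown below. What is called first, only, known or untested is meant among the compounds shown, and "the series" means these compounds.

Compound 1 `COC(=O)c1ccc(NCc2cncn2Cc2cccc(F)c2)cc1-c1ccccc1`: > 1000 nM (a limit of the assay)
Compound 2 `COC(=O)c1ccc(NCc2cncn2Cc2ccccc2C(C)(C)C)cc1-c1ccccc1`: "not determined" (no result reported)

Both compounds belong to a small series followed in a toxicity assay on NIH3T3 cells (Mus musculus) for cytotoxicity, read by resazurin assay (a lower number here means that less compound is needed, a higher number that more compound is needed for the effect), where the read-out is the half-maximal effective concentration. Compound 1 gives > 1000 nM in this assay, and this is a limit of the assay, not a number. Compound 2 has no number at all, since its entry reads "not determined" (no result reported). For the measured compounds named here, it therefore cannot be placed on the scale, and the only other reading available is the limit of > 1000 nM in this assay, at which 1 of the 2 values shown sits.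

Compound 3 `COC(=O)c1ccc(NCc2cncn2Cc2ccccc2[N+](=O)[O-])cc1-c1ccccc1` is the next structure to consider. The change is nitro in place of tert-butyl on an aromatic carbon, with nitro in place of tert-butyl on an aromatic carbon, ortho to a large group, so that 2-(tert-butyl)benzyl becomes 2-nitrobenzyl. Going by the values given here, no measured step gives the size of such a change in this assay. The expectation is therefore a modest one: no step beyond the usual scatter, with compound 3 staying in the region of compound 1, whose reading is the limit of > 1000 nM in this assay, at which 1 of the 2 values shown sits. Compound 3 is estimated at 5000 nM, with an expected range from 1200 nM to 30000 nM.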

Compound 3, half-maximal effective concentration: 10000 nM
Estimate against measurement, compound 3: 2.0-fold (0.30 log units) below; the measured number falls inside the stated range.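

No step can be read from compound 1 to compound 3, nor from compound 2 to compound 3: the reading for compound 1 is a limit of the assay, and compound 2 gives no number. The compounds shown leave open how 2-nitrophenyl compares in size of effect with 3-fluorophenyl or 2-(tert-butyl)phenyl.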